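Swapping hydroxy for isopropyl on an amino-linked phenyl ring

The compounds below may be only part of what the source reports. "The series", "measured", "known", "first", "only" and "open" are said of these compounds alone.

Measured so far:
Compound 1, `CN(c1ccccc1)c1ccc2c(c1)C(=O)N(C1CCC(=O)NC1=O)C2=O`: -2%
Compound 2, `O=C1CCC(N2C(=O)c3ccc(Nc4ccc(O)cc4)cc3C2=O)C(=O)N1`: 4%
Compound 3, `C=C(OCC)c1ccc(Nc2cccc3c2C(=O)N(C2CCC(=O)NC2=O)C3=O)cc1`: 10%

In an assay on FRT-Jurkat cells for inhibition of nuclear factor NF-kappa-B complex (Homo sapiens), read by flow cytometry, with a stated time of 24 h, tested at 10 uM (a lower number here means less inhibition, a higher number more inhibition at the concentration tested (going by the name of the read-out)), compound 2 gives 4%, the second highest of the three numbers, and its gaps to compound 1 and to compound 3 are both within the scatter. For the measured compounds named here, the one measured step, a number 6 percentage points higher from compound 1 to compound 2 (within the scatter), was also within the scatter. Compound 4, `CC(C)c1ccc(Nc2ccc3c(c2)C(=O)N(C2CCC(=O)NC2=O)C3=O)cc1`, differs from compound 2 by isopropyl in place of hydroxy on an aromatic carbon. Going by the values given here, no measured step touches this exact change, and the only step available moved the read-out little. The expected step is therefore a number 1 percentage points higher from compound 2 to compound 4 (within the scatter), not beyond the scatter. For compound 4 the estimate is 5%, expected to fall between -8% and 18%.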

Compound 4, a percentage reported as inhibition, at one concentration (the size of the read-out at that concentration, not a potency): 11%
Beside the measured number, compound 4's estimate is 6 percentage points below it; the range from low to high includes it.
By their numbers in this assay, from the lowest: compounds 1, 2, 3 and 4 (each within the scatter of the next, the first and the last beyond it).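

Isopropyl in place of hydroxy, on the aromatic carbon para to a large group, gives a number 7 percentage points higher from compound 2 to compound 4 (within the scatter) in this assay. The group that leaves carries a hydrogen-bond donor and acceptor and the one that enters carries neither, yet at this one concentration the read-out does not separate them. Nothing measured here explains why these two groups read alike.

Still open, as far as these compounds go, is whether an amine, a carboxylic acid or a longer chain at this place would move the read-out beyond the scatter. Also open, from the compounds shown here alone, is how either compound would behave at other concentrations.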